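The source may report more compounds than this note shows. Statements on the series, on what has been measured and on what is new or still open speak of the compounds shown alone.

Measured compounds in a physicochemical assay for acid dissociation:

compound 1, `C=CCN(C1=NCCN1)c1c(Br)cccc1Br`, gives 10.7
compound 2, `C=C(C)CN(C1=NCCN1)c1c(Br)cccc1Br`, gives 10.7
compound 3, `C=CCCN(C1=NCCN1)c1c(Br)cccc1Br`, gives 11.2

The change from compound 1 to compound 2 is methyl in place of hydrogen on a double-bonded chain carbon bound to a saturated chain carbon. In this assay this gave no change at the digits printed from compound 1 to compound 2 (within the scatter). Compound 4, `C=C(C)CCN(C1=NCCN1)c1c(Br)cccc1Br`, is not yet measured; it differs from compound 3 by methyl in place of hydrogen on a double-bonded chain carbon bound to a saturated chain carbon. Compound 3 differs from compound 1 by allyl in place of vinyl on a saturated chain carbon bound to a nitrogen on an aromatic ring, and in this assay that gave a number 0.50 log units higher from compound 1 to compound 3 (beyond the scatter). The place of the change is the same in both pairs, so the step from compound 3 to compound 4 is taken as the same change as that from compound 1 to compound 2. For compound 4 the expected step is no change at the digits printed from compound 3 to compound 4 (within the scatter), resting on compound 1 to compound 2 showing no change at the digits printed from compound 1 to compound 2 (within the scatter). Compound 4 is therefore estimated at 11.2 in this assay, between 10.8 and 11.6.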

Compound 4, acid dissociation constant: 10.9
For compound 4 the middle estimate is 0.30 log units above the measured one, and the stated range covers the measured number.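

In this assay, methyl in place of hydrogen on a double-bonded chain carbon bound to a saturated chain carbon gives a number 0.30 log units lower from compound 3 to compound 4 (within the scatter) and, in the other pair, no change at the digits printed from compound 1 to compound 2 (within the scatter), so across these two chain lengths the change stays within the scatter. The longer-chain comparisons agree, with a number 0.20 log units higher from compound 2 to compound 4 (within the scatter) and a number 0.20 log units higher from compound 1 to compound 4 (within the scatter), but two pairs on one shared core show nothing about other chains or other cores. Nothing measured here bears on the reason for these results.

Still open, on these data alone, is whether ethyl in place of that methyl, or a longer chain such as pent-4-en-1-yl, would behave the same way. Also open, as far as these compounds go, is whether the step holds with chlorine in place of bromine on the shared core.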